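The source may hold more compounds than are shown below. What is called first, only, known or untested is meant among the compounds shown, and "the series" means these compounds.

In a functional assay on SW480 cells (Homo sapiens) for cytotoxicity, read by MTT assay, with a stated time of 24 h (a lower number here means a stronger inhibitor, a higher number a weaker inhibitor), compound 1 `C=CC1=C(C(=O)Nc2ccccc2OC)C(c2ccc(F)cc2)OC1` gives only a limit of the assay, > 100000 nM. Compound 2 `C=CC1=C(C(=O)NCc2ccccc2F)C(c2ccc(F)cc2)OC1` likewise gives only a limit, > 100000 nM. Compound 3 `C=CC1=C(C(=O)NCc2ccccc2F)C(c2ccc(OC)cc2)OC1` also gives only a limit, > 100000 nM. The change from compound 2 to compound 1 is 2-methoxyphenyl in place of 2-fluorobenzyl on an amide-type nitrogen, and its step, a step that the two limits leave unreadable from compound 2 to compound 1, cannot be sized because of the limit of > 100000 nM in this assay, at which 3 of the 3 values shown sit. The change from compound 2 to compound 3 is methoxy in place of fluoro on an aromatic carbon; its step that the two limits leave unreadable from compound 2 to compound 3 is equally unreadable. Compound 4 `C=CC1=C(C(=O)Nc2ccccc2OC)C(c2ccc(OC)cc2)OC1`, not yet measured in this assay, differs from compound 3 by 2-methoxyphenyl in place of 2-fluorobenzyl on an amide-type nitrogen, the same change as from compound 2 to compound 1, made on a core that differs as just described. The step from compound 3 to compound 4 is expected to be a step that the limit leaves unreadable from compound 3 to compound 4, with every value sitting at the limit because of the limit of > 100000 nM in this assay, at which 3 of the 3 values shown sit. Compound 4 is therefore estimated at 200000 nM, between 100000 nM and 1000000 nM, most likely again reported only as a limit.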

Compound 4, half-maximal inhibitory concentration: > 100000 nM
Compound 4: a limit, no number; the forecaster's own chance of this, stated with the estimate: 85%; the middle value does not contradict the limit.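

Compound 4 gives only a limit, so its steps from compound 3 and from compound 1 cannot be read: the limit of > 100000 nM in this assay, at which 4 of the 4 values shown sit. As far as these compounds go, whether either change affects potency stays open: compound 1, compound 2, compound 3 and compound 4 all lack a number.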